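Removing a Hydroxy Group in Two Swapped Cores

The compounds below may be only part of what the source reports. "The series", "measured", "known", "first", "only" and "open" are said of these compounds alone.

Compound 1 `COc1ccc(-c2cccc(=O)n2-c2cc(OC)c(OC)c(OC)c2)cc1O`: in a functional assay on SK-OV-3 cells (Homo sapiens) for cytotoxicity, read by spectrophotometry, with a stated time of 72 h (on this read-out higher numbers stand for weaker inhibition and lower numbers for stronger inhibition), compound 1 gives < 10 nM, which is a limit of the assay.
Compound 2 `COc1ccc(-c2cccc(=O)n2-c2cc(OC)c(OC)c(OC)c2)cc1`: in this assay compound 2 gives < 10 nM, which is again a limit of the assay.
Among the compounds with values here, compound 3 `COc1ccc(-n2c(-c3cc(OC)c(OC)c(OC)c3)cccc2=O)cc1O`: in this assay compound 3 gives 1220 nM, the only number among the three.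

Compound 3 carries the same atoms as compound 1, joined differently; the difference between the two cores is not broken down here. From compound 1 to compound 2 the change is hydrogen in place of hydroxy on an aromatic carbon. The step that the two limits leave unreadable from compound 1 to compound 2 cannot be read, because of the limit of < 10 nM in this assay, at which 2 of the 3 values shown sit.

Compound 4 `COc1ccc(-n2c(-c3cc(OC)c(OC)c(OC)c3)cccc2=O)cc1` is not yet measured. It differs from compound 3 by hydrogen in place of hydroxy on an aromatic carbon, the same change as from compound 1 to compound 2, made on the same kind of place. Within the data shown here, since the only measured instance of this change leaves both ends at the limit, there is no readable step to carry over. The expectation is therefore a step of a 1.2-fold lower number from compound 3 to compound 4 (0.09 log units; within the scatter) in this assay that stays within the usual scatter, resting only on the absence of any readable step from compound 1 to compound 2. For compound 4 the estimate in this assay is 1000 nM, with an expected range from 300 nM to 3500 nM.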

Compound 4, half-maximal inhibitory concentration: 1540 nM
For compound 4 the middle estimate is 1.5-fold (0.19 log units) below the measured one, and the stated range covers the measured number.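

Replacing hydroxy with hydrogen, the change from 3-hydroxy-4-methoxyphenyl to 4-methoxyphenyl, gives a 1.3-fold higher number from compound 3 to compound 4 (0.10 log units; within the scatter) in this assay, so on this core the loss of the hydroxy group leaves no effect that can be told from the usual scatter. The same change on the other core cannot be read, and the two steps cannot be compared, because compound 1 and compound 2 both sit at a limit: the limit of < 10 nM in this assay, at which 2 of the 4 values shown sit. The series therefore offers one readable instance of the change, which shows neither that the step carries over from one core to the other nor that it differs between them, since a step of any size could lie hidden behind the limit.

As far as these compounds go, what the hydroxy group contributes on the core of compound 1 stays open, as the values shown for that core give no number to work from. Also open, from the compounds shown here alone, is whether another group at the same place on the core of compound 3, such as an amine, a fluorine atom or a carboxylic acid, would move the value in this assay beyond the scatter.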